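This account rests on a few compounds, and the source may have more. Where it says the series, first, only, none or still open, it means among the compounds named here.

Compound 1 `Cc1cc(C)c2c(O)cc(-c3ccc(Cl)cc3)nc2n1` carries a chlorophenyl group on a core that bears two methyl groups; in a functional assay on OVCAR-3 cells (Homo sapiens) (on this read-out lower numbers stand for stronger inhibition of growth and higher numbers for weaker inhibition of growth), compound 1 gives 18200 nM. Compound 3 `Cc1ccnc2nc(-c3ccc(Cl)cc3)cc(O)c12` keeps the chlorophenyl group and the core but lacks one methyl group, the change being (hydrogen in place of methyl on an aromatic carbon); in this assay compound 3 gives 3160 nM, a step of a 5.8-fold lower number from compound 1 to compound 3 (0.76 log units; beyond the scatter). Compound 2 `COc1cccc(-c2cc(O)c3c(C)cc(C)nc3n2)c1` carries a methoxyphenyl group instead; the difference between the core of compound 1 and the core of compound 2 is not broken down here. In this assay compound 2 gives 251 nM, the lowest number of the three. Compound 4 `COc1cccc(-c2cc(O)c3c(C)ccnc3n2)c1` arises from compound 2 by hydrogen in place of methyl on an aromatic carbon, the same change as from compound 1 to compound 3, with identical surroundings. A similar step is expected, a 4.6-fold lower number from compound 2 to compound 4 (0.66 log units; beyond the scatter), because of a 5.8-fold lower number from compound 1 to compound 3 (0.76 log units; beyond the scatter). Compound 4 is therefore estimated at 55 nM, within 18 nM to 180 nM.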

Compound 4, concentration for 50% growth inhibition: 25.7 nM
Estimate against measurement, compound 4: 2.1-fold (0.33 log units) above; low and high end bracket the measured number.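

In this assay, hydrogen in place of methyl on an aromatic carbon gives a step in the same direction on the second core: a 9.8-fold lower number from compound 2 to compound 4 (0.99 log units; beyond the scatter). The two steps do not differ beyond the scatter, so the change carries over from one core to the other here: the same change on two cores in this assay, a 5.8-fold lower number (0.76 log units; beyond the scatter) from compound 1 to compound 3 and a 9.8-fold lower number (0.99 log units; beyond the scatter) from compound 2 to compound 4, 1.7-fold (0.23 log units) apart, within the scatter of two such steps. For the compounds shown here, this rests on only two pairs in one assay, so it does not show that the step would hold on other cores or why the number falls.

The compounds shown leave open whether the step would persist with an amine or a carboxylic acid on the phenyl ring. They also leave open what an ethyl group or a longer chain would do in place of the remaining methyl group.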